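A few compounds are considered here, and "the series" means these few. Any claim that something is new, unique, unknown or untested is made for them only; others in the source may bear on it.

Measured compounds in a functional assay on A549 cells (Homo sapiens) for cytotoxicity, read by MTT assay, with a stated time of 24 h; on this read-out higher numbers stand for weaker inhibition and lower numbers for stronger inhibition:
- compound 1 `CNC(=O)Cn1nc(N)c2c(C(F)(F)F)cc(-c3ccccc3)nc21`: 15300 nM
- compound 2 `Nc1nn(CC(=O)NCCO)c2nc(-c3ccccc3)cc(C(F)(F)F)c12`: 128000 nM
- compound 3 `Nc1nn(CC(=O)N2CCCCC2)c2nc(-c3ccccc3)cc(C(F)(F)F)c12`: 1200 nM

Compound 1 stands second highest of the three numbers in this assay; the nearest is compound 2, the step being an 8.4-fold higher number from compound 1 to compound 2 (0.92 log units; beyond the scatter), and the furthest is compound 3, the step being a 13-fold lower number from compound 1 to compound 3 (1.11 log units; beyond the scatter).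

The unmeasured compound 4 `Nc1nn(CC(=O)N2CCCC2)c2nc(-c3ccccc3)cc(C(F)(F)F)c12` differs from compound 1 in one place: pyrrolidin-1-yl in place of methylamino on a carbonyl carbon.

Within the data shown here, the step that bears most directly on it is the one from compound 1 to compound 3, a 13-fold lower number from compound 1 to compound 3 (1.11 log units; beyond the scatter), where a cyclic amine also replaces methylamino on the carbonyl carbon. The step of a 110-fold lower number from compound 2 to compound 3 (2.03 log units; beyond the scatter) points the same way, while an 8.4-fold higher number from compound 1 to compound 2 (0.92 log units; beyond the scatter) shows the opposite move when a donor is added on that side chain. Piperidin-1-yl is the measured analogue; pyrrolidin-1-yl is the closest shape to it among the options, so a lower number is expected in this assay, probably beyond the scatter, though possibly not as far as with compound 3.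

For compound 4 the estimate in this assay is 2200 nM, with a range from 700 nM to 7000 nM, meaning an expected step of a 7.0-fold lower number from compound 1 to compound 4 (0.84 log units; beyond the scatter).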

Compound 4, half-maximal inhibitory concentration: 18700 nM
Estimate against measurement, compound 4: 8.5-fold (0.93 log units) below, and the stated range ends below it.
By their numbers in this assay, from the lowest: compound 3; then compounds 1 and 4 (each within the scatter of the next); then compound 2.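

In this assay, replacing methylamino with a cyclic amine on the carbonyl carbon does not in itself move the number: a 1.2-fold higher number from compound 1 to compound 4 (0.09 log units; within the scatter) stays within the scatter, even though the group's hydrogen-bond donor count goes from 1 to 0. The position does distinguish between the two cyclic amines, as a 16-fold higher number from compound 3 to compound 4 (1.19 log units; beyond the scatter) places pyrrolidin-1-yl well away from piperidin-1-yl, so the low number of compound 3 belongs to piperidin-1-yl rather than to cyclic amines generally, while a 6.8-fold lower number from compound 2 to compound 4 (0.84 log units; beyond the scatter) shows that (2-hydroxyethyl)amino remains apart from pyrrolidin-1-yl. No available evidence explains this difference between the two rings.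

As far as these compounds go, whether the low number extends to azepan-1-yl, morpholin-4-yl or 4-methylpiperidin-1-yl remains open. The compounds shown also leave open whether an acyclic dialkylamine such as diethylamino behaves like piperidin-1-yl or like pyrrolidin-1-yl.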